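A Side-Chain Change in an Amide Series

This account rests on a few compounds, and the source may have more. Where it says the series, first, only, none or still open, it means among the compounds named here.

Compound 1: `CC(C)[C@H](N)C(=O)Nc1cc2cc[nH]c(=O)c2cc1Cl` — 500 nM in a functional assay (aorta) with Rattus norvegicus as the target; a higher number here means that more compound is needed for the effect, a lower number that less compound is needed
Compound 2: `N[C@H]1CC[C@H](C(=O)Nc2cc3cc[nH]c(=O)c3cc2Cl)CC1` — "not determined" (no result reported) in this assay
Compound 3: `CC(C)(C)C[C@H](N)C(=O)Nc1cc2cc[nH]c(=O)c2cc1Cl` — "not determined" (no result reported) in this assay

Among the compounds with values here, compound 3 stands without a number of its own: nothing was reported for it in this assay, and compound 2 is in the same position, so the only measured value belongs to compound 1, which gives 500 nM. Compound 4, `CC(C)C[C@@H](N)C(=O)Nc1cc2cc[nH]c(=O)c2cc1Cl`, differs from compound 3 in one place: 1-amino-3-methylbutyl in place of 1-amino-3,3-dimethylbutyl on a carbonyl carbon. Within the data shown here, no step between the two can be read from the data. In this assay the change is expected to shift potency by no more than the usual scatter, because compound 1 with a related branched side chain gives 500 nM. Compound 4 is therefore estimated at 400 nM, with a range from 100 nM to 1600 nM.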

Compound 4, half-maximal effective concentration: 700 nM
Beside the measured number, compound 4's estimate is 1.8-fold (0.24 log units) below it; measured number inside the range.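

In this assay, within the data shown here, 1-amino-3-methylbutyl in place of 1-amino-2-methylpropyl on a carbonyl carbon gives a 1.4-fold higher number from compound 1 to compound 4 (0.15 log units; within the scatter) and so provides the first comparison at this position, where these two side chains cannot be told apart. Among these compounds, compound 2 and compound 3 have no value, so no steps to them can be read. No measured evidence accompanies this result to explain it.

Open, as far as these compounds go, is how a side chain of a different kind, such as one carrying a carboxylic acid or a phenyl ring, would fare here. Also open, from the compounds shown here alone, is what a hydroxyl group in place of the amine would give.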